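Trading a Pyridine Amide for a Trifluoromethylphenyl Amide

A few compounds are considered here, and "the series" means these few. Any claim that something is new, unique, unknown or untested is made for them only; others in the source may bear on it.

Three compounds share one core and differ only in the group on an amide-type nitrogen. Compound 1 `O=C(COc1ccc2cc(/C=C3/SC(=O)NC3=O)ccc2c1)Nc1cccc(Cl)c1` carries a 3-chlorophenyl there, compound 2 `Cc1cc(Br)ccc1NC(=O)COc1ccc2cc(/C=C3/SC(=O)NC3=O)ccc2c1` a 4-bromo-2-methylphenyl, and compound 3 `O=C(COc1ccc2cc(/C=C3/SC(=O)NC3=O)ccc2c1)Nc1ccccn1` a pyridin-2-yl. In an assay on isolated protein for inhibition of histone deacetylase 4 (Homo sapiens), with a stated time of 1 h (a higher number here means a weaker inhibitor, a lower number a stronger inhibitor), compound 1 gives 3800 nM, compound 2 gives 550 nM, and compound 3 gives 17000 nM. Compound 3 therefore has the highest number of the three and is the weakest inhibitor measured so far, as seen in a 4.5-fold higher number from compound 1 to compound 3 (0.65 log units; beyond the scatter) and in a 31-fold higher number from compound 2 to compound 3 (1.49 log units; beyond the scatter).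

Compound 4 `O=C(COc1ccc2cc(/C=C3/SC(=O)NC3=O)ccc2c1)Nc1cccc(C(F)(F)F)c1` is the next step from compound 3: 3-(trifluoromethyl)phenyl in place of pyridin-2-yl on an amide-type nitrogen. Read one bond further out, a (pyridin-2-yl)amino becomes a (3-(trifluoromethyl)phenyl)amino. The most relevant measured step is a 4.5-fold higher number from compound 1 to compound 3 (0.65 log units; beyond the scatter), since compound 1 also carries a carbon-only ring with a single substituent in the same position name, a 3-chlorophenyl. The step of a 6.9-fold lower number from compound 1 to compound 2 (0.84 log units; beyond the scatter) shows how much the choice of substituted phenyl can itself move the number. Undoing the pyridine exchange is expected to bring the number back roughly to where compound 1 stands, a modest drop.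

The value expected for compound 4 is 3500 nM, within a range from 1200 nM to 10000 nM. That estimate corresponds to an expected step of a 4.9-fold lower number from compound 3 to compound 4 (0.69 log units; beyond the scatter).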

Compound 4, half-maximal inhibitory concentration: 2500 nM
The estimate for compound 4 lay 1.4-fold (0.15 log units) above the measured number; measured number inside the range.
By their numbers in this assay, from the lowest: compound 2; then compounds 4 and 1 (each within the scatter of the next); then compound 3.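

The a 6.8-fold lower number from compound 3 to compound 4 (0.83 log units; beyond the scatter) in this assay shows that compound 1 was not a lone case: a second phenyl ring with a single substituent, here 3-(trifluoromethyl)phenyl, also gives a clearly stronger inhibitor than the pyridin-2-yl of compound 3. With a 1.5-fold lower number from compound 1 to compound 4 (0.18 log units; within the scatter), trifluoromethyl in place of chloro on an aromatic carbon cannot be told apart from the original compound in this assay, so at this position the two substituents give results that fall within the usual scatter, while a 4.5-fold higher number from compound 2 to compound 4 (0.66 log units; beyond the scatter) keeps compound 2, with its 4-bromo-2-methylphenyl, the strongest inhibitor of the four. Nothing measured here explains why these groups on the amide-type nitrogen rank as they do.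

The compounds shown leave open whether the bromo or the methyl of compound 2 matters more, since those two groups are only seen together on the ring. They also leave open how a methoxy group or a carboxylic acid on the phenyl ring would compare, and whether a trifluoromethyl group on the pyridine ring would recover the strength lost in compound 3.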